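Bromophenyl to chloromethylphenyl: a liver microsome half-life outlook

This account rests on a few compounds, and the source may have more. Where it says the series, first, only, none or still open, it means among the compounds named here.

Compound 1 `Nc1nc(NCCNc2ncc(-c3ncc[nH]3)c(-c3ccccc3Cl)n2)ccc1[N+](=O)[O-]` and compound 2 `Nc1nc(NCCNc2ncc(-c3ncc[nH]3)c(-c3ccccc3Br)n2)ccc1[N+](=O)[O-]` share one core and differ in a single place. In an ADME assay on microsomes from liver (Canis lupus familiaris) for metabolic stability (on this read-out lower numbers stand for a shorter-lived compound and higher numbers for a longer-lived compound), compound 1 gives > 0.5 h, which is a limit of the assay rather than a number. In this assay compound 2 gives > 0.5 h, again a limit and not a number. The step that the two limits leave unreadable from compound 1 to compound 2 therefore cannot be read in size or direction, since both values sit at the limit of > 0.5 h in this assay, at which 2 of the 2 values shown sit.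

Compound 3 `Cc1cc(Cl)ccc1-c1nc(NCCNc2ccc([N+](=O)[O-])c(N)n2)ncc1-c1ncc[nH]1` has not yet been measured in this assay. Its change from compound 2 is 4-chloro-2-methylphenyl in place of 2-bromophenyl on an aromatic carbon.

For the measured compounds named here, only one measured step concerns this position, and it is unreadable, so no measured size of change can be carried over. What is known is that compound 2 stands at the limit of this assay, and the expectation for compound 3 is that it stays near that limit as well. Compound 3 is therefore estimated at 1 h, with a range from 0.4 h to 3 h. The step that the limit leaves unreadable from compound 2 to compound 3 that this estimate means is expected to stay within the usual scatter.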

Compound 3, half-life: > 0.5 h
Compound 3: no number, only a limit; the forecaster's own chance of this, stated with the estimate: 65%; the middle value lies beyond the limit too.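

In this assay compound 3 gives > 0.5 h, again a limit and not a number, so the steps linking compound 3 to compound 1 and compound 2 cannot be read: the limit of > 0.5 h in this assay, at which 3 of the 3 values shown sit.

The compounds shown leave open how long any of the three actually lasts, and whether 4-chloro-2-methylphenyl in place of 2-bromophenyl changes the half-life at all.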